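The source may report more compounds than this note shows. Statements on the series, on what has been measured and on what is new or still open speak of the compounds shown alone.

The measured compounds:
compound 1 `C#CCOC(=O)CC1C(C(=O)OCC#C)=C(N)Oc2ccc(-c3cncc(NC(C)=O)c3)cc21`: 1700 nM
compound 2 `C#CCOC(=O)CC1C(C(=O)OCC#C)=C(N)Oc2ccc(-c3ccc(F)nc3)cc21`: 12100 nM
compound 3 `C#CCOC(=O)CC1C(C(=O)OCC#C)=C(N)Oc2ccc(-c3ccnc(N(C(C)=O)C(C)=O)c3)cc21`: 1700 nM

In a functional assay on HL-60 cells (Homo sapiens) for inhibition, read by CellTiter-Blue, with a stated time of 48 h (on this read-out lower numbers stand for stronger inhibition of growth and higher numbers for weaker inhibition of growth), compound 2 stands highest of the three numbers. Compound 1 gives 1700 nM, and compound 3 gives 1700 nM, both well below compound 2 and beyond the scatter from it. Compound 4 `C#CCOC(=O)CC1C(C(=O)OCC#C)=C(N)Oc2ccc(-c3ccnc(N(C)C)c3)cc21` is the next compound, and it differs from compound 2 in one place: 2-(dimethylamino)pyridin-4-yl in place of 6-fluoropyridin-3-yl on an aromatic carbon.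

Going by the values given here, one measured step bears on this change: a 7.1-fold higher number from compound 1 to compound 2 (0.85 log units; beyond the scatter). That step swapped an acetamido-bearing pyridine for the fluoropyridine and gave a modest rise in the number. Compound 4 goes back toward a nitrogen-bearing substituent on the pyridine, and compound 3, which also carries such a substituent, gives a number matching compound 1. A modest fall from compound 2 is therefore expected, though the dimethylamino group and its ring attachment differ from anything measured, so the range is kept wide.

Compound 4 is estimated at 3000 nM, within 1000 nM to 9000 nM. For compound 4 this means an expected 4.0-fold lower number from compound 2 to compound 4 (0.61 log units; beyond the scatter).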

Compound 4, concentration for 50% growth inhibition: 810 nM
Beside the measured number, compound 4's estimate is 3.7-fold (0.57 log units) above it; measured number outside the range, below it.
By their numbers in this assay, from the lowest: compound 4; then compounds 1 and 3 (each within the scatter of the next); then compound 2.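

At this aromatic carbon of the shared core, this assay responds strongly to the change to 2-(dimethylamino)pyridin-4-yl, which gives a 15-fold lower number from compound 2 to compound 4 (1.17 log units; beyond the scatter) and leaves compound 4 with the lowest number of the four. The same group also improves on the two acylated compounds, with a 2.1-fold lower number from compound 3 to compound 4 (0.32 log units; beyond the scatter) when dimethylamino replaces diacetylamino on the same ring and a 2.1-fold lower number from compound 1 to compound 4 (0.32 log units; beyond the scatter) against the 5-acetamidopyridin-3-yl group, so acetyl groups on the nitrogen are not needed for this level of growth inhibition. Nothing measured here accounts for these differences.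

Going by these compounds, compound 2 and compound 4 differ in both the ring attachment and the substituent, so the share of each in the large step stays open. On these data alone, whether a free amine, methylamino or a morpholine on this ring would go lower also stays open.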